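The source may hold more compounds than are shown below. What is called first, only, known or untested is meant among the compounds shown, and "the series" means these compounds.

Compound 1 `CNc1nccc2c1ncn2C1O[C@H](CO)[C@@H](O)[C@H]1O`: 8% in a functional assay (Homo sapiens) for inhibition of Nucleic Acid, tested at 100 uM; on this read-out higher numbers stand for more inhibition at the one concentration tested (going by the name of the read-out) and lower numbers for less inhibition
Compound 2 `[N-]=[N+]=Nc1nccc2c1ncn2C1O[C@H](CO)[C@@H](O)[C@H]1O`: 4%
Compound 3 `OC[C@H]1OC(n2cnc3c(NCc4ccccc4)nccc32)[C@H](O)[C@@H]1O`: 32%

Compound 3 gives the highest number of the three, with a number 24 percentage points higher from compound 1 to compound 3 (beyond the scatter) and a number 28 percentage points higher from compound 2 to compound 3 (beyond the scatter), both beyond the scatter. Compound 4 `CCNc1nccc2c1ncn2C1O[C@H](CO)[C@@H](O)[C@H]1O` differs from compound 3 by methyl in place of phenyl on a saturated chain carbon bound to a nitrogen on an aromatic ring. Within the data shown here, the step that bears on this is the one from compound 1 to compound 3, where the phenyl enters and the number rises by a number 24 percentage points higher from compound 1 to compound 3 (beyond the scatter); compound 4 keeps only a methyl in that place, so a drop of roughly that size is expected. Compound 4 is therefore estimated at 12%, between 0% and 28%, which means an expected step of a number 20 percentage points lower from compound 3 to compound 4 (beyond the scatter).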

Compound 4, a percentage reported as inhibition, at one concentration (the size of the read-out at that concentration, not a potency): 4%
Compound 4: the middle estimate sits 8 percentage points above what was measured; measured number inside the range.
By their numbers in this assay, from the lowest: compounds 2, 4 and 1 (each within the scatter of the next); then compound 3.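

Methyl in place of hydrogen on the saturated chain carbon gives a number 4 percentage points lower from compound 1 to compound 4 (within the scatter) and so does not reproduce the rise seen with phenyl, while a number 28 percentage points lower from compound 3 to compound 4 (beyond the scatter) shows that the higher number goes with phenyl there and not with just any added group. With no change at the digits printed from compound 2 to compound 4 (within the scatter) as well, ethylamino stands level with azido and methylamino, leaving benzylamino alone apart from the others. Nothing measured here explains why phenyl stands apart.

From the compounds shown here alone, whether a propyl chain, a cyclohexyl ring or a pyridine ring in that place would keep the higher number remains open. So does the effect of a chlorine or a methoxy group on the phenyl.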